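Tetrazole for sulfonic acid on a dithiocarbamate chain

This account rests on a few compounds, and the source may have more. Where it says the series, first, only, none or still open, it means among the compounds named here.

Compound 2 `O=S(=O)(O)CCCSC(=S)NCc1cccnc1` is the weaker of the two measured compounds in a functional assay on SK-BR-3 cells (Homo sapiens) for cytotoxicity, read by resazurin assay, with a stated time of 72 h (a higher number here means a weaker inhibitor, a lower number a stronger inhibitor), where compound 2 gives 6770 nM. Within the data shown here, compound 1 `CC(=O)CCSC(=S)NCc1cccnc1` is its only measured neighbour. In this assay, among the measured compounds shown here, compound 1 gives 1120 nM, and the step of a 6.0-fold higher number from compound 1 to compound 2 (0.78 log units; beyond the scatter) is the one measured change at this position. Compound 3 `S=C(NCc1cccnc1)SCCc1nnn[nH]1` alters the same place again: 1H-tetrazol-5-yl in place of sulfomethyl on a saturated chain carbon, two bonds along the chain from a sulfur. For the measured compounds named here, the only guidance is that a change at this place, acetyl to sulfomethyl, shifted the number modestly but beyond the scatter; nothing measured shows what a 1H-tetrazol-5-yl does there. The author therefore expects a step of a 1.9-fold lower number from compound 2 to compound 3 (0.29 log units; within the scatter) that could go either way, and leans toward a somewhat lower number than compound 2 because compound 1 with 1120 nM shows the chain end tolerates a different group. For compound 3 the estimate in this assay is 3500 nM, with a range from 900 nM to 14000 nM.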

Compound 3, half-maximal inhibitory concentration: > 100000 nM
Compound 3: only a limit was reported; the forecaster's own chance of this, stated with the estimate: 5%; at least 28-fold (1.45 log units) between middle value and limit.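

In this assay, compound 3 is reported only as a limit and not as a number: the limit of > 100000 nM in this assay, at which 1 of the 3 values shown sits. Replacing sulfomethyl with 1H-tetrazol-5-yl gives an at least 14-fold higher number from compound 2 to compound 3 (1.16 log units; beyond the scatter), and replacing acetyl with the same group gives an at least 89-fold higher number from compound 1 to compound 3 (1.95 log units; beyond the scatter); both are larger than the modest 6.0-fold higher number from compound 1 to compound 2 (0.78 log units; beyond the scatter). This place on the chain therefore does not accept every end group: acetyl and sulfomethyl both left a measurable number, whereas the five-membered aromatic ring with 4 hetero atoms did not.

The compounds shown do not say whether a carboxylic acid at this place, or the 1H-tetrazol-5-yl on a longer chain, would restore a measurable number. On these data alone, how far compound 3 lies past its limit also remains unknown.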